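Amide substituent at the ring nitrogen of the shared core

The compounds below may be only part of what the source reports. "The series", "measured", "known", "first", "only" and "open" are said of these compounds alone.

Compound 1 `O=C1NCCc2nc(C#Cc3ccccc3)sc21` gives 112 nM in an assay on HEK293 cells for positive allosteric modulation of metabotropic glutamate receptor 5 (Homo sapiens), read by FLIPR, with a stated time of 1 h; a lower number here means that less compound is needed, a higher number that more compound is needed for the effect. Compound 2 `Fc1cccc(C#Cc2nc3c(s2)CN(C2CCOC2)CC3)c1` returns only a limit in this assay, > 10000 nM. Compound 3 `CC(=O)N1CCc2nc(C#Cc3ccccc3)sc2C1` likewise returns only a limit, > 10000 nM, so compound 3 sits at the limit of > 10000 nM in this assay, at which 2 of the 3 values shown sit, with no number of its own. Compound 4 `CC1CCC(C(=O)N2CCc3nc(C#Cc4ccccc4)sc3C2)CC1` is not yet measured. The change from compound 3 to compound 4 is 4-methylcyclohexyl in place of methyl on a carbonyl carbon. No measured pair differing in one place is shown, and compound 1 differs from compound 3 in more than one place, so the size of the step is open; a step of either direction beyond the scatter is possible. The estimate for compound 4 is 2500 nM, between 300 nM and 10000 nM, which is expected to mean a step of an at least 4.0-fold lower number from compound 3 to compound 4 (0.60 log units; beyond the scatter).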

Compound 4, half-maximal effective concentration: 190 nM
For compound 4 the middle estimate is 13-fold (1.12 log units) above the measured one, outside the stated range (below it).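

In this assay, the acyl group on the carbonyl carbon proves decisive for this series: 4-methylcyclohexyl in place of methyl gives an at least 52-fold lower number from compound 3 to compound 4 (1.72 log units; beyond the scatter). Compound 3 gives > 10000 nM, which is a limit of the assay and not a number. The full size of the step therefore remains unknown, since it starts from a limit: the limit of > 10000 nM in this assay, at which 2 of the 4 values shown sit.

From the compounds shown here alone, whether the ring or its methyl carries the step remains open. Unsubstituted cyclohexyl, phenyl or a straight hexyl chain on the same carbonyl carbon would separate these possibilities.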